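The source may report more compounds than this note shows. Statements on the series, on what has been measured and on what is new or still open speak of the compounds shown alone.

Compound 1 `CN1C(=O)N(C)C2C1NC(=S)N2/N=C/C=C/c1ccccc1` gives 45700 nM in a functional assay on A549 cells (Homo sapiens) for inhibition, read by MTT assay, with a stated time of 72 h; on this read-out higher numbers stand for weaker inhibition and lower numbers for stronger inhibition. Compound 2 `CN1C(=O)N(C)C2C1NC(=S)N2/N=C/C=C/c1ccccc1[N+](=O)[O-]` gives 2720 nM in this assay.

Among the compounds with values here, compound 1 thus gives the higher of the two numbers; the sole comparison available is a 17-fold lower number from compound 1 to compound 2 (1.23 log units; beyond the scatter). Compound 3 `COc1ccc(/C=C/C=N/N2C(=S)NC3C2N(C)C(=O)N3C)cc1` differs from compound 1 by methoxy in place of hydrogen on an aromatic carbon. Within the data shown here, only the step from compound 1 to compound 2 bears on this change, and it concerned a different group, so it guides only loosely. Compound 3 is therefore expected to lie a 2.3-fold lower number from compound 1 to compound 3 (0.36 log units; beyond the scatter). Compound 3 is estimated at 20000 nM, within 6000 nM to 60000 nM.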

Compound 3, half-maximal inhibitory concentration: > 100000 nM
Compound 3: no number, only a limit; the forecaster's own chance of this, stated with the estimate: 10%; middle value at least 5.0-fold (0.69 log units) away from the limit.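

In this assay, within the data shown here, going from phenyl to 4-methoxyphenyl gives an at least 2.1-fold higher number from compound 1 to compound 3 (0.34 log units; beyond the scatter), so methoxy at this place, para to a large group, weakens inhibition, whereas the only earlier step, with nitro, ran the other way: a 17-fold lower number from compound 1 to compound 2 (1.23 log units; beyond the scatter). Substitution on this ring of compound 1 therefore does not act in one direction across the compounds shown. The entry for compound 3 is a limit and not a number: the limit of > 100000 nM in this assay, at which 1 of the 3 values shown sits.

The compounds shown leave open how an amine, a hydroxyl or a chlorine at this same place would read. They also leave open whether nitro para to the large group would give the stronger inhibition seen with compound 2.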